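The compounds below may be only part of what the source reports. "The series", "measured", "known", "first", "only" and "open" are said of these compounds alone.

Measured in a functional assay on MCF7 cells (Homo sapiens) for antiproliferative activity, read by CCK-8 assay, with a stated time of 48 h; a lower number here means a stronger inhibitor, a higher number a weaker inhibitor:
- compound 1 `C=CC(=O)NCCOc1ccc(Oc2c(-c3ccc(F)cc3)sc3cc(O)ccc23)cc1`: 23000 nM
- compound 2 `C=C(C)C(=O)NCCOc1ccc(Oc2c(-c3ccc(F)cc3)sc3cc(O)ccc23)cc1`: > 25000 nM

Compound 2 stands at > 25000 nM, which is a limit of this assay and not a number. The evidence so far holds (the limit of > 25000 nM in this assay, at which 1 of the 2 values shown sits).

Compound 3 `C/C=C/C(=O)NCCOc1ccc(Oc2c(-c3ccc(F)cc3)sc3cc(O)ccc23)cc1` has the same atoms as compound 2, joined differently: prop-1-en-1-yl in place of 1-methylethenyl on a carbonyl carbon. In words, prop-1-en-1-yl stands in place of 1-methylethenyl on a carbonyl carbon.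

Among the compounds with values here, one measured step bears on this change, an at least 1.0-fold higher number from compound 1 to compound 2 (0.03 log units; that floor lies within the scatter), with methyl in place of hydrogen on a double-bonded chain carbon bound to a carbonyl carbon. Within the data shown here, with that step as the only guide, no step beyond the scatter is expected in this assay, in either direction. The estimated step is a number no higher from compound 2 to compound 3 (the limit leaves the size open).

The expected value for compound 3 is 25000 nM, with an estimated range from 12000 nM to 50000 nM.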

Compound 3, half-maximal inhibitory concentration: 21700 nM
Compound 3: the middle estimate sits 1.2-fold (0.06 log units) above what was measured, within the range that was stated.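

In this assay, prop-1-en-1-yl in place of vinyl on the carbonyl carbon gives a 1.1-fold lower number from compound 1 to compound 3 (0.03 log units; within the scatter), so the read-out does not separate these two groups. Compound 2 stands at > 25000 nM, which is a limit of this assay and not a number. Prop-1-en-1-yl in place of 1-methylethenyl gives an at least 1.1-fold lower number from compound 2 to compound 3 (0.06 log units; that floor lies within the scatter), so the two arrangements of the same carbons are not told apart so far, and the true size of this step stays open because one end of it is a limit: the limit of > 25000 nM in this assay, at which 1 of the 3 values shown sits.

Whether any group on this carbonyl carbon can move the number beyond the scatter remains open, since no step shown is beyond it. A longer chain or an amine carried on the prop-1-en-1-yl group would test this.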